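The source may report more compounds than this note shows. Statements on the series, on what has been measured and on what is new or still open speak of the compounds shown alone.

Measured compounds:
- compound 1 `COc1cc(N2C(N)=C(C#N)C(c3ccc(OC)c4ccccc34)C3=C2CC(C)(C)CC3=O)cc(OC)c1OC` gives 40%
- compound 2 `COc1cc(N2C(N)=C(C#N)C(c3cccc([N+](=O)[O-])c3)C3=C2CC(C)(C)CC3=O)cc(OC)c1OC` gives 30%

Both were tested in a functional assay on Ehrlich cells (Mus musculus) for cytotoxicity, tested at 100 ug/mL; on this read-out higher numbers stand for a stronger effect at the one concentration tested and lower numbers for a weaker effect. Among the measured compounds shown here, compound 2 gives the lower of the two numbers, but the only step available, a number 10 percentage points lower from compound 1 to compound 2 (within the scatter), is no larger than the scatter of this kind of measurement, so the two compounds cannot be told apart on these data.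

Compound 3 `COc1cc(N2C(N)=C(C#N)C(c3ccc(C)cc3)C3=C2CC(C)(C)CC3=O)cc(OC)c1OC` has not yet been measured. It differs from compound 2 in one place: 4-methylphenyl in place of 3-nitrophenyl on a saturated ring carbon. For the measured compounds named here, the single measured step concerns the same position, where a 4-methoxynaphthalen-1-yl group was exchanged for a 3-nitrophenyl group, and that exchange did nothing beyond the scatter. Going by the values given here, no measured pair shows what happens when 4-methylphenyl takes this position, so there is no direct evidence either way. On what is known, a step of about a number 5 percentage points higher from compound 2 to compound 3 (within the scatter) is expected, that is, no change beyond the scatter. Compound 3 is therefore estimated at 35%, with a range from 15% to 55%.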

Compound 3, a percentage reported as activity, at one concentration (the size of the read-out at that concentration, not a potency): 90%
Estimate against measurement, compound 3: 55 percentage points below; measured number above the stated range.
By their numbers in this assay, from the lowest: compounds 2 and 1 (each within the scatter of the next); then compound 3.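

Among the compounds shown here, the position on the saturated ring carbon looked insensitive while only two groups had been compared, but it now proves able to change the result strongly: in this assay, replacing 3-nitrophenyl with 4-methylphenyl gives a number 60 percentage points higher from compound 2 to compound 3 (beyond the scatter) and replacing 4-methoxynaphthalen-1-yl with 4-methylphenyl gives a number 50 percentage points higher from compound 1 to compound 3 (beyond the scatter). Both steps lie beyond the scatter, so compound 3 stands clearly apart from the two earlier compounds, which still cannot be told apart from each other, and the choice of group at this one place is enough to separate them in this test. Nothing measured here explains why this exchange has so large an effect.

The compounds shown leave open whether the methyl group matters in itself, and a plain phenyl ring, a 4-ethylphenyl group or a 4-aminophenyl group at this position would help to settle that. On these data alone, they also leave open whether a 3-methylphenyl group would behave like the 4-methylphenyl group, and since each number comes from one concentration, how potent compound 3 is remains unknown.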